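This account rests on a few compounds, and the source may have more. Where it says the series, first, only, none or still open, it means among the compounds named here.

Working notes on the series.

Of the compounds shown here, two of the shared core have been measured in an assay on membranes from CHO cells for displacement of a labelled ligand from adenosine receptor A1 (Homo sapiens), read by scintillation counting, with a stated time of 60 min, tested at 1 uM; on this read-out higher numbers stand for more inhibition at the one concentration tested (going by the name of the read-out) and lower numbers for less inhibition. Compound 1, `CCCOC(=O)C1=C(C)NC(=O)NC1c1ccsc1`, gives 44% in this assay. Compound 2, `CCNC(=O)C1=C(C)NC(=O)NC1c1ccco1`, gives 2% in this assay. Compound 2 thus stands lowest of the two numbers recorded; its nearest neighbour is compound 1, whose value lies higher by a gap that exceeds the usual scatter. Among the compounds with values here, compounds 1 and 2 differ in more than one place, so no single step between them can be read from these two values; they show only that one member of the pair displaces far more of the labelled ligand than the other.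

The next compound is compound 3, `CCNC(=O)C1=C(C)NC(=O)NC1c1ccsc1`, which differs from compound 2 by thiophen-3-yl in place of furan-2-yl on a saturated ring carbon. Compound 3 carries the ethylcarbamoyl group of compound 2 together with the thiophen-3-yl group found in compound 1. Within the data shown here, with no single-change step recorded, the size of the step in this assay is open; an upward step is expected, since compound 1 with 44% holds the same thiophen-3-yl group, but its magnitude is uncertain. Compound 3 is therefore estimated at 20% in this assay, with an expected range from 2% to 45%, implying an expected step of a number 18 percentage points higher from compound 2 to compound 3 (beyond the scatter).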

Compound 3, a percentage reported as inhibition, at one concentration (the size of the read-out at that concentration, not a potency): 3%
Beside the measured number, compound 3's estimate is 17 percentage points above it, within the range that was stated.
By their numbers in this assay, from the lowest: compounds 2 and 3 (each within the scatter of the next); then compound 1.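

In this assay, the exchange of furan-2-yl for thiophen-3-yl on a saturated ring carbon, with the ethylcarbamoyl group held constant, gives a number 1 percentage points higher from compound 2 to compound 3 (within the scatter), so this pair does not separate the two rings at this position. The exchange of propoxy for ethylamino on a carbonyl carbon, with thiophen-3-yl held constant, gives a number 41 percentage points lower from compound 1 to compound 3 (beyond the scatter), which places the large difference among the compounds shown at the carbonyl substituent and not at the ring. No measurement at hand bears on the reason for either result.

From the compounds shown here alone, the ring exchange has been read only with the ethylcarbamoyl group in place, where both numbers are small, so it remains open whether furan-2-yl and thiophen-3-yl would also stand together in a compound carrying the propoxy group. Going by these compounds, it also remains open how the reading would respond to other groups on the carbonyl carbon, such as a shorter ethoxy chain, a longer butoxy chain or a free carboxylic acid, or to a phenyl ring on the saturated ring carbon.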